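A few compounds are considered here, and "the series" means these few. Any claim that something is new, unique, unknown or untested is made for them only; others in the source may bear on it.

Measured so far in a functional assay on U-251 cells (Homo sapiens) for antiproliferative activity, read by MTT assay, with a stated time of 24 h; on this read-out higher numbers stand for weaker inhibition and lower numbers for stronger inhibition:
Compound 1 `COc1cccc(C(=O)Oc2ccc3c(=O)c(-c4cc(OC)c(OC)cc4OC)coc3c2)c1` gives > 10000 nM, a limit of the assay and not a number.
Compound 2 `COc1cc(OC)c(-c2coc3cc(OCc4ccc(F)cc4)ccc3c2=O)cc1OC` gives 3200 nM.
Compound 3 `COc1cc(OC)c(-c2coc3cc(OCc4ccc([N+](=O)[O-])cc4)ccc3c2=O)cc1OC` gives 9400 nM.

Among the measured compounds shown here, compound 3 stands highest of the two numbers; the step of a 2.9-fold higher number from compound 2 to compound 3 (0.47 log units; beyond the scatter) separates it from the only other number. Compound 4 `COc1cc(OC)c(-c2coc3cc(OCc4ccccc4Br)ccc3c2=O)cc1OC` differs from compound 3 by 2-bromophenyl in place of 4-nitrophenyl on a saturated chain carbon bound to an oxygen on an aromatic ring. For the measured compounds named here, no measured step makes this exact exchange. The closest is a 2.9-fold higher number from compound 2 to compound 3 (0.47 log units; beyond the scatter), where nitro in place of fluoro raised the number; the change to compound 4 removes that nitro and brings in a different halogen, bromine. Compound 4 is therefore expected to give a lower number than compound 3, by a 2.4-fold lower number from compound 3 to compound 4 (0.37 log units; beyond the scatter). The estimate for compound 4 is 4000 nM, between 1500 nM and 11000 nM.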

Compound 4, half-maximal inhibitory concentration: > 10000 nM
Compound 4: only a limit was reported (the forecaster's own chance of this, stated with the estimate: 15%); middle value at least 2.5-fold (0.39 log units) from the limit.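

In this assay compound 4 gives > 10000 nM, which is a limit and not a number. Carrying a halogen does not by itself keep the number low at this position: 2-bromophenyl in place of 4-fluorophenyl gives an at least 3.1-fold higher number from compound 2 to compound 4 (0.49 log units; beyond the scatter), while 2-bromophenyl in place of 4-nitrophenyl gives only an at least 1.0-fold higher number from compound 3 to compound 4 (0.02 log units; that floor lies within the scatter), so those two compounds cannot be ordered. The step between the two limits cannot be read, and the assay limit now hides differences at the weak end: the limit of > 10000 nM in this assay, at which 2 of the 4 values shown sit.

Still open, going by these compounds, is how an unsubstituted benzyl would behave on this oxygen. So is a benzyl carrying an amine or a carboxylic acid.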